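This account rests on a few compounds, and the source may have more. Where it says the series, first, only, none or still open, it means among the compounds named here.

Measured so far in a functional assay on HBL-100 cells (Homo sapiens) for cytotoxicity, read by MTT assay, with a stated time of 72 h; a higher number here means a weaker inhibitor, a lower number a stronger inhibitor:
Compound 1 `COc1ccc(-c2cc(=O)oc3ccccc23)cc1O`: 84 nM
Compound 2 `COc1ccc(-c2cc(=O)oc3cccc(OC)c23)cc1O`: 182 nM

Of these two, compound 2 carries the higher number, 182 nM, and so is the weaker inhibitor. Compound 3 `COc1ccc(-c2cc(=O)oc3ccc(OC)c(OC)c23)cc1O` differs from compound 2 by methoxy in place of hydrogen on an aromatic carbon, a methoxy in place of hydrogen on an aromatic carbon, ortho to a methoxy group. Going by the values given here, one measured step bears on this, the same kind of replacement elsewhere on the ring system: a 2.2-fold higher number from compound 1 to compound 2 (0.34 log units; beyond the scatter). On that modest precedent, a further modest rise in this assay is expected, though a single step is thin evidence. The expected step is a 1.6-fold higher number from compound 2 to compound 3 (0.22 log units; within the scatter). Compound 3 is estimated at 300 nM, with an expected range of 110 nM to 800 nM.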

Compound 3, half-maximal inhibitory concentration: 439 nM
Estimate against measurement, compound 3: 1.5-fold (0.17 log units) below, and the stated range covers the measured number.
By their numbers in this assay, from the lowest: compound 1; then compound 2; then compound 3.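

In this assay, a methoxy in place of hydrogen, ortho to a methoxy group, brings a 2.4-fold higher number from compound 2 to compound 3 (0.38 log units; beyond the scatter), so the rise recurs at a second place on the same ring. Compound 3 thus extends the trend: each added methoxy among these compounds goes with a higher number, and none goes against it. No measured evidence accounts for this rise.

What the compounds shown leave open is whether this position would respond the same way to an amine or a longer chain such as ethoxy. Also open, from the compounds shown here alone, is what a methoxy here would do without the neighbouring methoxy.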